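A few compounds are considered here, and "the series" means these few. Any claim that something is new, unique, unknown or untested is made for them only; others in the source may bear on it.

Three compounds share one core, an amide carried by a piperidine whose nitrogen bears a cinnamyl-type chain, and differ only in the group on the amide-type nitrogen. Compound 1 `Cc1ccc(NC(=O)C2CCN(C/C=C/c3ccccc3)CC2)cc1` carries a 4-methylphenyl there; in a functional assay on MGC-803 cells (Homo sapiens) for inhibition, read by MTT assay, with a stated time of 72 h (on this read-out higher numbers stand for weaker inhibition and lower numbers for stronger inhibition), compound 1 gives 24100 nM, the lowest number of the three, although compound 3 stands within the scatter of it. Compound 2 `COc1ccccc1NC(=O)C1CCN(C/C=C/c2ccccc2)CC1` gives 71200 nM and compound 3 `N#Cc1ccc(NC(=O)C2CCN(C/C=C/c3ccccc3)CC2)cc1` gives 28200 nM.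

Compound 4 `O=C(NCc1ccccc1)C1CCN(C/C=C/c2ccccc2)CC1` is the next step from compound 1: benzyl in place of 4-methylphenyl on an amide-type nitrogen. The measured steps that touch this same place are a 3.0-fold higher number from compound 1 to compound 2 (0.47 log units; beyond the scatter) and a 1.2-fold higher number from compound 1 to compound 3 (0.07 log units; within the scatter); a swap between two of the aryl groups, a 2.5-fold lower number from compound 2 to compound 3 (0.40 log units; beyond the scatter), was of similar size. Going by the values given here, no measured step exchanges an aryl group for a benzyl on this nitrogen, so those steps show only that changes at this position have so far moved the number modestly or not beyond the scatter. For compound 4 a shift of similar size is expected, a 1.2-fold higher number from compound 1 to compound 4 (0.10 log units; within the scatter), in no firmly known direction. Compound 4 is therefore estimated at 30000 nM, with a range from 12000 nM to 75000 nM.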

Compound 4, half-maximal inhibitory concentration: > 100000 nM
Compound 4: only a limit was reported; the forecaster's own chance of this, stated with the estimate: 10%; at least 3.3-fold (0.52 log units) between middle value and limit.
By their numbers in this assay, from the lowest: compounds 1 and 3 (each within the scatter of the next); then compound 2. At a limit, above all of these: compound 4.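

Going by these compounds alone, the benzyl swap exchanges two groups made of the same atoms, joined differently, yet it is the first change on this amide-type nitrogen to produce a limit rather than a number. For compound 4, this assay gives only a limit: the limit of > 100000 nM in this assay, at which 1 of the 4 values shown sits. Set against the two lowest numbers, this gives an at least 4.1-fold higher number from compound 1 to compound 4 (0.61 log units; beyond the scatter) and an at least 3.5-fold higher number from compound 3 to compound 4 (0.54 log units; beyond the scatter), while the remaining step is less telling, an at least 1.4-fold higher number from compound 2 to compound 4 (0.14 log units; that floor lies within the scatter), so it settles no order.

How far compound 4 lies past the limit stays unknown, and the compounds shown do not explain why this rearrangement of atoms matters. Also open, on these data alone, is where other groups on this nitrogen would fall, such as a plain phenyl or a 2-phenylethyl chain.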